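A few compounds are considered here, and "the series" means these few. Any claim that something is new, unique, unknown or untested is made for them only; others in the source may bear on it.

Measured compounds:
compound 1 `COC(=O)c1cc(-c2cccc(NC(=O)c3ccc(/C=C/C(=O)c4cccnc4)cc3)c2)on1` — in an ADME assay on Vero cells (Chlorocebus sabaeus) for cytotoxicity, read by MTT assay, with a stated time of 72 h (a higher number here means that more compound is tolerated, a lower number that less compound is tolerated), compound 1 gives "not determined" (no result reported)
compound 2 `COC(=O)c1cc(-c2cccc(NC(=O)c3ccc(/C=C/C(=O)c4ccc(C)c(F)c4)cc3)c2)on1` — compound 2 gives > 50 ug/mL, a limit of this assay
compound 3 `CCCOc1ccc(C(=O)/C=C/c2ccc(C(=O)O)cc2)cc1` — compound 3 gives < 10 ug/mL, a limit of this assay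

Compound 1 stands without a number of its own in this assay; the two other values shown are limits, not numbers. For compound 2 the value sits at the limit of > 50 ug/mL in this assay, at which 1 of the 3 values shown sits. For compound 3 the value sits at the limit of < 10 ug/mL in this assay, at which 1 of the 3 values shown sits. Compound 4 `COC(=O)c1cc(-c2cccc(NC(=O)c3ccc(C4OC4C(=O)c4ccc(Cl)cc4)cc3)c2)on1` differs from compound 1 by 3-((4-chlorophenyl)carbonyl)oxiran-2-yl in place of 2-((pyridin-3-yl)carbonyl)ethenyl on an aromatic carbon. Among the measured compounds shown here, no step between measured compounds is available here, so for this change no direction can be read from the series, and a step in this assay of no more than the usual scatter is expected. Compound 4 is expected to give about 35 ug/mL, in the range 12 ug/mL to 80 ug/mL.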

Compound 4, half-maximal cytotoxic concentration: > 20 ug/mL
Compound 4 was reported as a limit (the forecaster's own chance of this, stated with the estimate: 40%); the middle value does not contradict the limit.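

Among the compounds shown here, compound 2 and compound 4 both stand as limits in this assay, and no step between them can be read. Still open, on these data alone, is how the 3-((4-chlorophenyl)carbonyl)oxiran-2-yl group compares with either ethenyl group on the shared core.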